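Cyclohexyl to 5-hydroxypentyl on the amide of compound 1

The source may report more compounds than this note shows. Statements on the series, on what has been measured and on what is new or still open speak of the compounds shown alone.

Compound 1 `COc1cccc2cc(C(=O)NC3CCCCC3)c(=N)oc12` carries a cyclohexyl group on its amide nitrogen. In an assay on CHO cells for displacement of a labelled ligand from adenosine receptor A1 (Homo sapiens), read by scintillation counting, with a stated time of 60 min, tested at 10 uM (on this read-out lower numbers stand for less inhibition and higher numbers for more inhibition at the one concentration tested (going by the name of the read-out)), compound 1 gives 40%, the highest of the two plain numbers in hand. Compound 3 `COc1cccc2cc(C(=O)N[C@@H](CO)C(=O)O)c(=O)oc12`, which bears a serine-derived substituent on the amide and a carbonyl on the core, gives 12% in this assay, a reading that lies beyond the usual scatter below compound 1. Compound 2 `COC(=O)/C(C#N)=C/c1cccc(OC)c1O` is an open-chain cinnamate-type nitrile rather than a bicyclic amide; for compound 2 this assay reports only a limit, > 70%, and not a number (the limit of > 70% in this assay, at which 1 of the 3 values shown sits).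

Compound 4 `COc1cccc2cc(C(=O)NCCCCCO)c(=N)oc12` has not yet been measured in this assay. Relative to compound 1 the change is 5-hydroxypentyl in place of cyclohexyl on an amide-type nitrogen. Among the measured compounds shown here, no pair of measured compounds differs in only one place, so there is no measured step to lean on; the only pointer is that compound 3, with a hydroxyl-bearing amide substituent, sits well below compound 1 even though it differs at the core as well: compound 1 gives 40%, whereas compound 3 gives 12%.

The expectation is a moderate drop, a step of a number 15 percentage points lower from compound 1 to compound 4 (beyond the scatter). For compound 4 the estimate in this assay is 25%, within a range from 5% to 50%.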

Compound 4, a percentage reported as inhibition, at one concentration (the size of the read-out at that concentration, not a potency): 44%
For compound 4 the middle estimate is 19 percentage points below the measured one; low and high end bracket the measured number.
By their numbers in this assay, from the lowest: compound 3; then compounds 1 and 4 (each within the scatter of the next). At a limit, above all of these: compound 2.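

Among the compounds shown here, replacing cyclohexyl with 5-hydroxypentyl on the amide-type nitrogen gives the first single-place step: in this assay, the step is a number 4 percentage points higher from compound 1 to compound 4 (within the scatter), so the two readings stand level within the scatter. At this position, on the shared core, the six-membered carbon ring is therefore not required to keep the reading, and an open chain ending in a hydroxyl, with the hydrogen-bond donor and acceptor counted for 5-hydroxypentyl, serves in its place without a readable difference. Nothing in the data on hand bears on why this swap leaves the reading where it is.

As far as these compounds go, whether a primary amine or a carboxylic acid in place of the terminal hydroxyl, or a longer chain than 5-hydroxypentyl, would hold the reading in this assay stays open. From the compounds shown here alone, the read-out is taken at one concentration and is not a potency, and how compound 1 and compound 4 compare in potency also stays open.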